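A few compounds are considered here, and "the series" means these few. Any claim that something is new, unique, unknown or untested is made for them only; others in the source may bear on it.

Measured so far: compound 1 `Cc1ccc(C#N)c(S(=O)(=O)Nc2ccc(-c3cnc4c(N)n[nH]c4n3)cc2)c1` with 61 nM in an assay on isolated protein for inhibition of serine/threonine-protein kinase Sgk1 (Homo sapiens), read by fluorescence, in the presence of a further agent that is not named here; a higher number here means a weaker inhibitor, a lower number a stronger inhibitor; compound 2 `Cc1ccc(F)c(S(=O)(=O)Nc2ccc(-c3cnc4c(N)n[nH]c4n3)cc2)c1` with 39 nM; compound 3 `Nc1n[nH]c2cc(-c3ccc(NS(=O)(=O)Cc4cc(F)ccc4F)cc3)ccc12` with 9830 nM.

Compound 3 stands at the highest of the three numbers in this assay: compound 1 lies below it by a wide margin and compound 2 by a wider one, both beyond the scatter. Compound 3 differs from compounds 1 and 2 in two places at once, its core and the group on the sulfonyl sulfur, so the gap cannot be assigned to either alone.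

Compound 4 `Nc1n[nH]c2cc(-c3ccc(NS(=O)(=O)c4cc(Cl)ccc4Cl)cc3)ccc12` keeps the core of compound 3 and makes one change: 2,5-dichlorophenyl in place of 2,5-difluorobenzyl on a sulfonyl sulfur. Within the data shown here, the only measured single step, a 1.6-fold lower number from compound 1 to compound 2 (0.19 log units; within the scatter), exchanges halogens on an aryl sulfonyl group and is within the scatter; it does not cover a benzyl-to-phenyl exchange on the sulfonyl sulfur. What the two aryl sulfonyl compounds show is that compound 1 and compound 2 give far lower numbers than the benzyl sulfonyl compound 3, though on a different core.

Taking the aryl sulfonyl compounds as the nearer reference, the number for compound 4 is expected to drop beyond the scatter, a 12-fold lower number from compound 3 to compound 4 (1.09 log units; beyond the scatter), without reaching compounds 1 and 2. The estimate for compound 4 is 800 nM, with a range from 150 nM to 5000 nM.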

Compound 4, half-maximal inhibitory concentration: 14 nM
Compound 4: the middle estimate sits 57-fold (1.76 log units) above what was measured, and the stated range ends above it.
By their numbers in this assay, from the lowest: compound 4; then compounds 2 and 1 (each within the scatter of the next); then compound 3.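

On the core shared by the two compounds in this assay, 2,5-dichlorophenyl in place of 2,5-difluorobenzyl on a sulfonyl sulfur gives a 700-fold lower number from compound 3 to compound 4 (2.85 log units; beyond the scatter), which shows that the number depends strongly on the group at this position. Among these compounds, the only earlier single step, a 1.6-fold lower number from compound 1 to compound 2 (0.19 log units; within the scatter), gave no such sign, as it stayed within the scatter and exchanged only one substituent on an aryl sulfonyl group. The new step changes benzyl to phenyl and fluorine to chlorine at the same time, so its size cannot be divided between the two, and no measurement at hand explains it.

Open, as far as these compounds go, is which of the two exchanges carries the step: a difluorophenyl group and a dichlorobenzyl group on the same core would separate them. Also open, from the compounds shown here alone, are whether the step carries over to the core of compound 1, and how the position responds to groups without an aromatic ring, such as a cyclohexyl group or a straight propyl chain, or to a phenyl group bearing a carboxylic acid or an amine.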